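Cytotoxicity Across a Shared Core: From Acid to Amine

The compounds below may be only part of what the source reports. "The series", "measured", "known", "first", "only" and "open" are said of these compounds alone.

In an ADME assay on Vero cells (Chlorocebus sabaeus) for cytotoxicity (on this read-out lower numbers stand for higher toxicity in this test and higher numbers for lower toxicity in this test), compound 2 `O=C(O)CCC(=O)Nc1ccc(-c2nc3cc(C(F)(F)F)ccc3[nH]2)cc1` reaches only the limit of the test, giving > 100000 nM. Compound 1 `Cn1c(-c2ccc(NC(=O)CN3CCCC3)cc2)nc2cc(C(F)(F)F)ccc21` likewise gives > 100000 nM in this assay, a limit and not a number. Compound 3 `CC(=O)Nc1ccc(-c2nc3cc([N+](=O)[O-])ccc3[nH]2)cc1` also stands at a limit, with > 100000 nM in this assay. Within the data shown here, all three therefore sit together on the same line, (the limit of > 100000 nM in this assay, at which 3 of the 3 values shown sit), so compound 2 stands exactly where its neighbours do, and no measured step separates any pair of them. Compound 4 `CCN(CC)CC(=O)Nc1ccc(-c2nc3cc(C(F)(F)F)ccc3[nH]2)cc1` has not yet been measured in this assay; it differs from compound 2 in one place, (diethylamino in place of carboxymethyl on a saturated chain carbon bound to a carbonyl carbon). With every value shown resting at the limit, no size or direction of step can be read from the measured compounds for this change. The step is expected to be none beyond the scatter, a number no higher from compound 2 to compound 4 (the limit leaves the size open). Compound 4 is estimated at 100000 nM in this assay, within a range from 30000 nM to 300000 nM, and most likely reported again only as a limit.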

Compound 4, half-maximal cytotoxic concentration: 24000 nM
Beside the measured number, compound 4's estimate is 4.2-fold (0.62 log units) above it; the whole stated range lies above it.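

In this assay, among these compounds, the change from carboxymethyl to diethylamino on a saturated chain carbon bound to a carbonyl carbon brings an at least 4.1-fold lower number from compound 2 to compound 4 (0.61 log units; beyond the scatter) and is the first measured step at this position. The position is therefore not silent in this test, and the step runs toward higher toxicity in this test, although neither the leaving nor the entering group carries a net charge. Compound 4 is also the only compound shown with a true number rather than a limit: the limit of > 100000 nM in this assay, at which 3 of the 4 values shown sit.

Going by these compounds, how far the number would fall with the diethylamino group replaced by a primary amine, a piperidine ring or a longer chain stays open. The compounds shown also leave open whether the step comes from the entry of the amine or from the loss of the carboxylic acid.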